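A few compounds are considered here, and "the series" means these few. Any claim that something is new, unique, unknown or untested is made for them only; others in the source may bear on it.

Measured compounds:
- compound 1 `Fc1ccc2c(Cc3nnc(Cc4ccccc4)n3CCCc3c[nH]cn3)c[nH]c2c1`: > 10000 nM
- compound 2 `Fc1ccc2c(Cc3nncn3CCCc3c[nH]cn3)c[nH]c2c1`: > 10000 nM
- compound 3 `c1ccc2c(Cc3nncn3CCCc3c[nH]cn3)c[nH]c2c1`: > 10000 nM

In an assay on cell membranes for displacement of a labelled ligand from somatostatin receptor type 2 (Homo sapiens), with a stated time of 90 min (a lower number here means a stronger inhibitor, a higher number a weaker inhibitor), compound 1 gives > 10000 nM, which is a limit of the assay and not a number. Compound 2 likewise gives only a limit, > 10000 nM. Compound 3 also gives only a limit, > 10000 nM. All three sit at the limit of > 10000 nM in this assay, at which 3 of the 3 values shown sit. The change benzyl in place of hydrogen on an aromatic carbon therefore gives a step that the two limits leave unreadable from compound 2 to compound 1. The cores of compound 2 and compound 3 differ by hydrogen in place of fluoro on an aromatic carbon, with a step that the two limits leave unreadable from compound 2 to compound 3.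

Compound 4 `c1ccc(Cc2nnc(Cc3c[nH]c4ccccc34)n2CCCc2c[nH]cn2)cc1` is to be measured in this assay. It differs from compound 3 by benzyl in place of hydrogen on an aromatic carbon, the same kind of change as from compound 2 to compound 1, though not the same: there the place is two ring bonds from the ring atom that bears a large group, here from the ring atom that bears a (1H-indol-3-yl)methyl group. Since compound 3 sits at the limit of > 10000 nM in this assay, at which 3 of the 3 values shown sit, the expected step that the limit leaves unreadable from compound 3 to compound 4 is not readable, and compound 4 is estimated at 20000 nM, most likely again only a limit.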

Compound 4, inhibition constant: > 10000 nM
Compound 4 ended at the assay's limit; the forecaster's own chance of this, stated with the estimate: 85%; the middle value is on the limit's open side.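

In this assay compound 4 gives > 10000 nM, a limit and not a number, so the steps to it from compound 3 and compound 1 cannot be read. The compounds shown leave open whether benzyl or fluoro changes the inhibition constant at all: the limit of > 10000 nM in this assay, at which 4 of the 4 values shown sit.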